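The source may hold more compounds than are shown below. What is called first, only, known or untested is meant among the compounds shown, and "the series" means these compounds.

Working notes on the series. Among the compounds with values here, in an assay on THP-1 cells for displacement of a labelled ligand from C-C chemokine receptor type 1 (Homo sapiens) (a lower number here means a stronger inhibitor, a higher number a weaker inhibitor), compound 1 `CC(C)[C@@H](NC(=O)CCc1ccc(F)cc1)C(=O)N1CCC(c2ccc(Cl)cc2)CC1` gives 70 nM, the lowest of the three numbers measured so far. Compound 2 `O=C(N[C@@H](C(=O)N1CCC(c2ccc(Cl)cc2)CC1)C1CCCCC1)c1ccccc1` gives 121 nM in this assay, which sits within the scatter of compound 1, so no order between the two is claimed. Compound 3 `CC(C)C(NC(=O)OCc1ccccc1)C(=O)N1CCC(c2ccc(Cl)cc2)CC1` gives 1080 nM, clearly beyond the scatter from compound 1 and the weakest of the three.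

The next compound is compound 4 `CC(C)[C@@H](NC(=O)Nc1ccccc1)C(=O)N1CCC(c2ccc(Cl)cc2)CC1`. Its change from compound 1 is anilino in place of 2-(4-fluorophenyl)ethyl on a carbonyl carbon. Within the data shown here, no measured pair in the set shows this change directly, so the expected step rests on the spread of the three values shown. A modest rise, at about the edge of the scatter, is expected: a 2.1-fold higher number from compound 1 to compound 4 (0.33 log units; beyond the scatter). Compound 4 is therefore estimated at 150 nM, within a range from 45 nM to 550 nM.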

Compound 4, half-maximal inhibitory concentration: 616 nM
Compound 4: the middle estimate sits 4.1-fold (0.61 log units) below what was measured, and the stated range ends below it.
By their numbers in this assay, from the lowest: compounds 1 and 2 (each within the scatter of the next); then compounds 4 and 3 (each within the scatter of the next).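

Anilino in place of 2-(4-fluorophenyl)ethyl on a carbonyl carbon gives an 8.8-fold higher number from compound 1 to compound 4 (0.94 log units; beyond the scatter) in this assay and is the first direct reading at this position, which clearly does not treat these two aromatic groups alike. Both carry one six-membered aromatic ring of carbon only, yet the change also alters the chain, adds the anilino hydrogen-bond donor and removes fluorine, so the step cannot be assigned to any one of these. No evidence on hand bears on the cause of this rise.

On these data alone, whether the nitrogen, the chain length or the fluorine governs the step stays open. Benzylamino or plain 2-phenylethyl on the same carbonyl carbon would help separate these.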